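The source may report more compounds than this note shows. Statements on the series, on what has been measured and on what is new or still open speak of the compounds shown alone.

Compound 1 `Cc1cccc2c1nc(COc1ccc(Cl)cc1)n2CCCC1CCN(C)CC1` is the reference point of the series. Among the compounds with values here, in an assay on AV12 cells for binding affinity to Neuropeptide Y receptor type 1 (Homo sapiens) (a higher number here means a weaker inhibitor, a lower number a stronger inhibitor), compound 1 gives 52 nM, the lowest of the two numbers measured so far, with compound 2 `Cc1cccc2c1nc(COc1ccc(Cl)cc1)n2CCCC1CCN(CCCc2ccccc2)CC1` beside it at 57 nM; the step of a 1.1-fold higher number from compound 1 to compound 2 (0.04 log units; within the scatter) shows that placing phenethyl on the saturated chain carbon bound to the amine nitrogen in the ring leaves the number essentially unchanged.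

Compound 3 `CCOC(=O)CN1CCC(CCCn2c(COc3ccc(Cl)cc3)nc3c(C)cccc32)CC1` is not yet measured. It differs from compound 1 as follows: ethoxycarbonyl in place of hydrogen on a saturated chain carbon bound to an amine nitrogen in a ring. Within the data shown here, the only measured step that bears on this is the one from compound 1 to compound 2, which changes the same position and stays within the scatter. Among the measured compounds shown here, no measured step probes ethoxycarbonyl itself. On that basis the step of a 1.2-fold higher number from compound 1 to compound 3 (0.06 log units; within the scatter) is expected to stay within the scatter in this assay. For compound 3 the estimated value in this assay is 60 nM, with a range of 25 nM to 150 nM.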

Compound 3, inhibition constant: 427 nM
Estimate against measurement, compound 3: 7.1-fold (0.85 log units) below; the whole stated range lies below it.
By their numbers in this assay, from the lowest: compounds 1 and 2 (each within the scatter of the next); then compound 3.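

In this assay the place on a saturated chain carbon bound to an amine nitrogen in a ring proves sensitive to what enters it: the step of an 8.2-fold higher number from compound 1 to compound 3 (0.91 log units; beyond the scatter) lies beyond the scatter, unlike the earlier step at this place. The step of a 7.5-fold higher number from compound 2 to compound 3 (0.87 log units; beyond the scatter) is also beyond the scatter, so a substituent here is not tolerated as such; phenethyl leaves the number within the scatter of compound 1, while ethoxycarbonyl does not. Nothing at hand explains this difference between the two groups.

Open, going by these compounds, is whether the loss belongs to the ester as a whole or to part of it. A carboxylic acid, a primary amide or a simple ketone at this place could separate these, and a longer chain between the ring nitrogen and the ester could show whether distance from that nitrogen matters.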